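This account rests on a few compounds, and the source may have more. Where it says the series, first, only, none or still open, it means among the compounds named here.

Working notes on the series. Three compounds have numbers in an assay on isolated protein (strain Sprague-Dawley) for inhibition of Amine oxidase [flavin-containing] B (Rattus norvegicus), read by spectrophotometry, with a stated time of 5 min; on this read-out higher numbers stand for weaker inhibition and lower numbers for stronger inhibition. Compound 1 `O=c1cc(O)c2ccc(OCc3cccc(F)c3)cc2o1` gives 2090 nM; compound 2 `O=c1cc(O)c2ccc(OCc3cccc(Br)c3)cc2o1` gives 490 nM; compound 3 `CN(C)C(=O)COc1cc(=O)oc2cc(OCc3cccc(Cl)c3)ccc12` gives 501 nM. Compound 3 stands second highest of the three: its number and that of compound 2 sit within the scatter of each other, while compound 1 sits beyond the scatter, at a higher number. Within the data shown here, the one step between compounds that differ in a single place, a 4.3-fold lower number from compound 1 to compound 2 (0.63 log units; beyond the scatter), concerns the halogen on the benzyl ring and says nothing about the group on the shared core.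

Compound 4 `NC(=O)c1cc(=O)oc2cc(OCc3cccc(Cl)c3)ccc12` is not yet measured. It differs from compound 3 in carbamoyl in place of (dimethylcarbamoyl)methoxy on an aromatic carbon. Among the measured compounds shown here, no measured step bears on this change; the only step available, a 4.3-fold lower number from compound 1 to compound 2 (0.63 log units; beyond the scatter), sits elsewhere on the molecule. The expectation for this assay therefore rests on compound 3 alone, with no direction claimed, so compound 4 is expected to show a 1.2-fold higher number from compound 3 to compound 4 (0.08 log units; within the scatter), that is to land near compound 3, within a wide range. Compound 4 is estimated at 600 nM, with the range 150 nM to 2500 nM.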

Compound 4, half-maximal inhibitory concentration: 234 nM
Estimate against measurement, compound 4: 2.6-fold (0.41 log units) above; the range from low to high includes it.
By their numbers in this assay, from the lowest: compound 4; then compounds 2 and 3 (each within the scatter of the next); then compound 1.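

Carbamoyl in place of (dimethylcarbamoyl)methoxy gives a 2.1-fold lower number from compound 3 to compound 4 (0.33 log units; beyond the scatter) in this assay, a modest step and the first measured change at this aromatic carbon opposite the ring oxygen. Among these compounds, the position therefore affects the number, and here the smaller carbamoyl, the only one of the two groups with a hydrogen-bond donor, gives the lower value. Among the compounds shown here, the single step cannot separate the loss of the chain from the gain of that donor, and no supporting evidence accounts for the shift.

On these data alone, whether a carboxylic acid, an amine or a longer chain ending in a primary amide would follow compound 4 remains open. As far as these compounds go, compounds 1 and 2 differ from compound 4 in more than one place, so how the group at this position acts alongside other benzyl halogens also remains open.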